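A few compounds are considered here, and "the series" means these few. Any claim that something is new, unique, unknown or untested is made for them only; others in the source may bear on it.

Within the data shown here, in an ADME assay on the whole organism for pharmacokinetics, with Rattus norvegicus as the target, at a dose of 5 mg/kg by the oral route (on this read-out higher numbers stand for higher exposure at the dose given and lower numbers for lower exposure), compound 1 `CC(C)(O)c1ccc(-c2cnc3c(n2)N(CCC2CCOCC2)C(=O)CN3)cn1` gives 5560 ng.h/mL and compound 2 `COCCN1C(=O)CNc2ncc(-c3ccc(C(C)(C)O)nc3)nc21` gives 9960 ng.h/mL; these are the only two numbers, and they lie within the scatter of each other. Compound 3 `CO[C@H]1CC[C@@H](CN2CC(=O)Nc3ncc(-c4ccc(C(C)(C)O)nc4)nc32)CC1` has no number: "not determined" (no result reported). Compound 4 `CO[C@H]1CC[C@H](N2C(=O)CNc3ncc(-c4ccc(C(C)(C)O)nc4)nc32)CC1` is unmeasured and has the same atoms as compound 1, joined differently: 4-methoxycyclohexyl in place of 2-(oxan-4-yl)ethyl on an amide-type nitrogen in a ring. Among the measured compounds shown here, no measured step makes this exact change. For the measured compounds named here, the nearest evidence is the one measured step at this amide-type nitrogen, a 1.8-fold higher number from compound 1 to compound 2 (0.25 log units; within the scatter), so no step beyond the scatter is expected, with weak support from a single pair. The expected change is a 1.3-fold higher number from compound 1 to compound 4 (0.13 log units; within the scatter). For compound 4 the estimated value is 7500 ng.h/mL, with an expected range of 2500 ng.h/mL to 20000 ng.h/mL.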

Compound 4, area under the concentration-time curve: 10300 ng.h/mL
Compound 4: middle estimate off by 1.4-fold (0.14 log units), on the low side; the measured number falls inside the stated range.
By their numbers in this assay, from the lowest: compounds 1, 2 and 4 (each within the scatter of the next).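

At this amide-type nitrogen in a ring, this assay shows a 1.9-fold higher number from compound 1 to compound 4 (0.27 log units; within the scatter) and also a 1.0-fold higher number from compound 2 to compound 4 (0.01 log units; within the scatter) when 4-methoxycyclohexyl enters. A carbon-only ring with 2 defined stereocentres therefore reads the same, within the scatter, as 2-(oxan-4-yl)ethyl and 2-methoxyethyl, so all three groups at this position are indistinguishable on this read-out. No supporting data explain these numbers. As far as these compounds go, whether an amine or a carboxylic acid on this nitrogen would give a step beyond the scatter remains open, as does the effect of the other stereoisomer of 4-methoxycyclohexyl.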